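Compound 1 and a one-group exchange

This account rests on a few compounds, and the source may have more. Where it says the series, first, only, none or still open, it means among the compounds named here.

Values in an ADME assay for permeability, using PAMPA, at pH 7.4 (on this read-out higher numbers stand for higher permeability and lower numbers for lower permeability), so far:
- compound 1 `COc1ccc(-c2nc3ccccc3o2)cc1NC(=O)c1cc([N+](=O)[O-])ccc1Cl` gives 274 10^-6 cm/s
- compound 2 `O=C(Nc1ccc(-c2ccccc2)cc1)c1cc([N+](=O)[O-])ccc1Cl` gives 26 10^-6 cm/s
- compound 3 `Cc1cc(NC(=O)c2cc([N+](=O)[O-])ccc2Cl)cc(-c2nc3ccccc3s2)c1O` gives 48 10^-6 cm/s

Compound 1 stands highest of the three, and the gap to each of the others lies beyond the usual scatter. The nearest is compound 3 (at 48 10^-6 cm/s) and the furthest is compound 2 (at 26 10^-6 cm/s).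

The next compound to be measured is compound 4 `COc1ccc(-c2nc3ccccc3s2)cc1NC(=O)c1cc([N+](=O)[O-])ccc1Cl`, which keeps the core of compound 1 and differs from it in one place (1,3-benzothiazol-2-yl in place of 1,3-benzoxazol-2-yl on an aromatic carbon). The exchange sits on an aromatic carbon, meta to a large group and para to a methoxy group.

Among the compounds with values here, no measured pair isolates a change of this kind, so the size of the step has no direct precedent here. Compound 3 also carries 1,3-benzothiazol-2-yl and gives 48 10^-6 cm/s but it differs from compound 1 elsewhere too, so it offers only a weak hint of direction. A modest fall is therefore expected, and the estimated step is a 1.8-fold lower number from compound 1 to compound 4 (0.26 log units; within the scatter) with no firm expectation of a move beyond the scatter.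

In this assay compound 4 is expected at 150 10^-6 cm/s with an estimated range from 60 10^-6 cm/s to 350 10^-6 cm/s when it is measured.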

Compound 4, apparent permeability: "below limit of detection" (no number reported)
No number was reported for compound 4; the estimate stays without a comparison.
By their numbers in this assay, from the lowest: compounds 2 and 3 (each within the scatter of the next); then compound 1.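

In this assay, within the data shown here, compound 4 is reported as below the limit of detection, with no number, and so no step from compound 1 to compound 4 can be read. Nothing available bears on the reason for this result. The compounds shown leave open how large the change is on exchanging 1,3-benzoxazol-2-yl for 1,3-benzothiazol-2-yl.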